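The source may report more compounds than this note shows. Statements on the series, on what has been measured and on what is new or still open speak of the compounds shown alone.

Compound 1 `CCC1(Cc2ccccc2)OS(=O)(=O)C=C1OCc1ccc(OC)cc1` was examined in an ADME assay on HEL cells (Homo sapiens) for cytotoxicity, with a stated time of 3 days; a lower number here means that less compound is tolerated, a higher number that more compound is tolerated. In this assay compound 1 returns only a limit, > 200000 nM, a limit of the measurement rather than a number, and it sits at the limit of > 200000 nM in this assay, at which 1 of the 2 values shown sits. Compound 2 `CCC1(CC)OS(=O)(=O)C=C1OCc1ccccc1` gives 200000 nM in this assay. Compound 3 `CCC1(Cc2ccccc2)OS(=O)(=O)C=C1OCc1ccc(Br)cc1` carries bromo in place of methoxy on an aromatic carbon relative to compound 1. No measured step for such a change is shown, so no shift in this assay beyond the usual scatter is expected. The step expected is a number no higher from compound 1 to compound 3 (the limit leaves the size open), small in size. Compound 3 is estimated at 200000 nM, in a range from 100000 nM to 400000 nM.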

Compound 3, half-maximal cytotoxic concentration: 171000 nM
The estimate for compound 3 lay 1.2-fold (0.07 log units) above the measured number, and the stated range covers the measured number.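

Bromo in place of methoxy on an aromatic carbon turns a limit into a measured number, and the change reads as an at least 1.1-fold lower number from compound 1 to compound 3 (0.06 log units; that floor lies within the scatter). Thus, the 4-methoxyphenyl to 4-bromophenyl change shows no shift beyond the usual scatter in this assay. Compound 1 has only a limit, which leaves the full size of the step unread: the limit of > 200000 nM in this assay, at which 1 of the 3 values shown sits.

The compounds shown leave open whether an amine or a carboxylic acid on that aromatic carbon would move the number in this assay. They also leave open what a longer chain in place of the ethyl group on the shared core would do.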